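A few compounds are considered here, and "the series" means these few. Any claim that something is new, unique, unknown or untested is made for them only; others in the source may bear on it.

In a functional assay for inhibition, with Homo sapiens as the target (a higher number here means a weaker inhibitor, a lower number a stronger inhibitor), compound 1 (`O=C(O)CCCCCCCCn1nc(-c2ccccc2)cc1-c1ccccc1`) reads > 66000 nM, which is a limit and not a number. Among the measured compounds shown here, compound 2 (`O=C(O)COCCCCCCn1nc(-c2ccccc2)c(-c2ccccc2)c1-c1ccccc1`) gives 440 nM, the only true number so far. Compound 3 (`N#CCCCCCCCCn1nc(-c2ccccc2)c(-c2ccccc2)c1-c1ccccc1`) is not yet measured and differs from compound 2 by 2-cyanoethyl in place of carboxymethoxy on a saturated chain carbon, six bonds along the chain from an aromatic nitrogen. For the measured compounds named here, no measured pair isolates this change, so the expectation is tentative: weaker inhibition in this assay, well beyond the scatter, with an expected step of a 45-fold higher number from compound 2 to compound 3 (1.66 log units; beyond the scatter). The estimated value for compound 3 is 20000 nM, within a range of 2500 nM to 100000 nM.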

Compound 3, half-maximal inhibitory concentration: > 72000 nM
Compound 3 gave a limit, no number; the forecaster's own chance of this, stated with the estimate: 55%; middle value at least 3.6-fold (0.55 log units) from the limit.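

In this assay, 2-cyanoethyl in place of carboxymethoxy on a saturated chain carbon, six bonds along the chain from an aromatic nitrogen, gives an at least 160-fold higher number from compound 2 to compound 3 (2.21 log units; beyond the scatter). Compound 3 stands at a limit and not at a number, so the step is a floor: the limit of > 72000 nM in this assay, at which 1 of the 3 values shown sits. The loss of a measurable value with this one change could not be read from compound 1, which differs from compound 2 in more than one place.

The compounds shown do not separate the carboxylic acid from the ether oxygen within carboxymethoxy. A tetrazole or a primary amide in this place on the same core would test whether anything other than carboxymethoxy keeps a measurable value.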